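The source may hold more compounds than are shown below. What is called first, only, known or untested is meant among the compounds shown, and "the series" means these compounds.

Of the compounds shown here, two have been measured in a functional assay on SF-268 cells (Homo sapiens) for inhibition, read by sulforhodamine B assay, with a stated time of 72 h; on this read-out lower numbers stand for stronger inhibition and higher numbers for weaker inhibition. Compound 1 `O=c1[nH]c2ccc(Br)cc2nc1/C=C/c1ccc(Br)cc1` gives 0.0407 ug/mL in this assay. Compound 2 `Cc1nc2cc(Br)ccc2nc1N1CCCCC1` gives 0.0304 ug/mL in this assay, the lowest of the two numbers, though compound 1 sits close enough that the gap lies within the scatter, so neither can be called the stronger of the pair.

Compound 3 `Cc1nc2cc(Br)ccc2nc1NN` has not yet been measured. It differs from compound 2 in one place: aminoamino in place of piperidin-1-yl on an aromatic carbon. The change removes a six-membered non-aromatic ring with one hetero atom and puts two nitrogen atoms in its place, carrying two hydrogen-bond donors where there were none.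

Among the measured compounds shown here, no measured pair in this set shows what such an exchange does in this assay, so any expectation rests on the size of the change alone. A loss of this much of the group is expected to cost some activity, with the step of a 9.9-fold higher number from compound 2 to compound 3 (0.99 log units; beyond the scatter) likely larger than the scatter but uncertain in size. Compound 3 is therefore estimated at 0.3 ug/mL, with a plausible range from 0.05 ug/mL to 2 ug/mL.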

Compound 3, half-maximal inhibitory concentration: 0.0168 ug/mL
Compound 3: middle estimate off by 18-fold (1.25 log units), on the high side, and the stated range ends above it.
By their numbers in this assay, from the lowest: compounds 3, 2 and 1 (each within the scatter of the next, the first and the last beyond it).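

In this assay, the exchange of piperidin-1-yl for aminoamino on this aromatic carbon, next to the ring nitrogen and ortho to a methyl group, gives a 1.8-fold lower number from compound 2 to compound 3 (0.26 log units; within the scatter), so the pair cannot be told apart. The earlier compounds shown here could not show this: at this position, the six-membered non-aromatic ring can be lost and hydrogen-bond donors brought in without a step beyond the scatter, so for this pair the ring is not needed to keep the number at this level. No measurement at hand explains why so large a change in the group leaves the read-out within the scatter.

As far as these compounds go, this is a single exchange at a single place, so it remains open whether a plain amino group, a methylamino group or a morpholine ring at the same carbon would also stay within the scatter of compound 2. Compound 1 differs from both in more than one place and offers no comparison, which leaves open what the methyl group and the bromine on the shared core contribute to the read-out.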